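The source may hold more compounds than are shown below. What is called first, only, known or untested is meant among the compounds shown, and "the series" means these compounds.

For the measured compounds named here, compound 1 `COc1ccc(C(=O)/C=C/c2nc3ccccc3cc2-c2ccc(OC)cc2)cc1` is the first of two measured compounds in a functional assay on A549 cells (Homo sapiens) for antiproliferative activity, read by XTT assay, with a stated time of 72 h (on this read-out higher numbers stand for weaker inhibition and lower numbers for stronger inhibition), where compound 1 gives 8500 nM. Compound 2 `COc1ccc(-c2cc3ccccc3nc2/C=C/C(=O)c2ccc([N+](=O)[O-])cc2)cc1` carries a nitro in place of methoxy on an aromatic carbon, and in this assay compound 2 gives 6310 nM; the step is a 1.3-fold lower number from compound 1 to compound 2 (0.13 log units; within the scatter). On the numbers shown, compound 2 therefore stands alongside compound 1, the two values lying within the scatter of each other, so neither can be called the stronger.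

Compound 3 `COc1ccc(-c2cc3ccccc3nc2/C=C/C(=O)c2c[nH]c3ccccc23)cc1` is not yet measured. Relative to compound 2 the change is 1H-indol-3-yl in place of 4-nitrophenyl on a carbonyl carbon. Going by the values given here, no measured step touches the group on the carbonyl carbon: the only step on record, a 1.3-fold lower number from compound 1 to compound 2 (0.13 log units; within the scatter), concerns the aromatic carbon at the other end and was within the scatter. That step gives no guidance on the size or direction of the present change, so the expectation for compound 3 rests on the near-constancy of the two values seen and is kept wide. Compound 3 is estimated at 5000 nM, with a range from 1500 nM to 16000 nM, a step of a 1.3-fold lower number from compound 2 to compound 3 (0.10 log units; within the scatter) that is expected, not measured.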

Compound 3, half-maximal inhibitory concentration: > 10000 nM
Compound 3 was reported as a limit; the forecaster's own chance of this, stated with the estimate: 5%; middle value at least 2.0-fold (0.30 log units) away from the limit.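

For the compounds shown here, with 1H-indol-3-yl on the carbonyl carbon, this position carries for the first time a group other than 4-methoxyphenyl or 4-nitrophenyl, one that adds a five-membered aromatic ring and a hydrogen-bond donor. Compound 3 is reported only as a limit, not as a number: the limit of > 10000 nM in this assay, at which 1 of the 3 values shown sits. The steps can therefore be read only as floors, an at least 1.5-fold higher number from compound 2 to compound 3 (0.19 log units; that floor lies within the scatter) and an at least 1.1-fold higher number from compound 1 to compound 3 (0.07 log units; that floor lies within the scatter), and since neither floor passes the scatter, the change is not shown to weaken inhibition, while nothing in the reading points to stronger inhibition either.

As far as these compounds go, how far compound 3 really lies from compound 1 and compound 2 stays open, and so does whether the hydrogen on the indole nitrogen has any part in the result, which a 1-methyl-1H-indol-3-yl group at the same carbon would address. Also open, from the compounds shown here alone, is how a plain phenyl, or a phenyl carrying an amine or a carboxylic acid, would read at this carbonyl carbon in this assay, as the two values from the phenyl compounds lie within the scatter of each other.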